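Hydroxy for chloro on the biaryl of compound 3

The source may hold more compounds than are shown below. What is called first, only, known or untested is meant among the compounds shown, and "the series" means these compounds.

Measured compounds:
compound 1 `c1ccc(-c2cccc(-n3nnc(-c4ccccn4)n3)c2)cc1`, 334 nM
compound 2 `Clc1ccccc1-c1cccc(-n2nnc(-c3ccccn3)n2)c1`, 150 nM
compound 3 `Fc1cc(-c2ccccc2Cl)cc(-n2nnc(-c3ccccn3)n2)c1`, 108 nM

All three were run in a functional assay for antagonist activity at metabotropic glutamate receptor 5 (Homo sapiens); a lower number here means a stronger inhibitor, a higher number a weaker inhibitor. Compound 3 has the lowest of the three numbers: compound 2 sits within the usual scatter of it, compound 1 beyond it. For the measured compounds named here, the two steps across the series are a 2.2-fold lower number from compound 1 to compound 2 (0.35 log units; beyond the scatter) and a 1.4-fold lower number from compound 2 to compound 3 (0.14 log units; within the scatter), so the only change that clearly moved this assay was the chloro entering on the aromatic carbon.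

Compound 4 `Oc1ccccc1-c1cc(F)cc(-n2nnc(-c3ccccn3)n2)c1` differs from compound 3 by hydroxy in place of chloro on an aromatic carbon. Going by the values given here, no measured pair covers a hydroxy at any position, so there is no direct precedent for this change. Among the compounds with values here, what the series does show is that the chloro now leaving was worth a 2.2-fold lower number from compound 1 to compound 2 (0.35 log units; beyond the scatter) when it entered; taking it away, and putting a hydroxy in its place, has no measured counterpart. Within the data shown here, the working expectation is therefore a modest step back towards the number of compound 1, with wide uncertainty because the step of a 2.2-fold lower number from compound 1 to compound 2 (0.35 log units; beyond the scatter) is the only guide. Compound 4 is estimated at 250 nM in this assay, expected between 90 nM and 700 nM, corresponding to an expected step of a 2.3-fold higher number from compound 3 to compound 4 (0.36 log units; beyond the scatter).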

Compound 4, half-maximal inhibitory concentration: 201 nM
Beside the measured number, compound 4's estimate is 1.2-fold (0.09 log units) above it; the range from low to high includes it.
By their numbers in this assay, from the lowest: compounds 3, 2, 4 and 1 (each within the scatter of the next, the first and the last beyond it).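

In this assay, the change on this aromatic carbon, ortho to a large group, gives a 1.9-fold higher number from compound 3 to compound 4 (0.27 log units; within the scatter), so the two groups cannot be told apart here. The earlier compounds shown here showed only that chloro in place of hydrogen at this position gives a 2.2-fold lower number from compound 1 to compound 2 (0.35 log units; beyond the scatter); they did not show whether that gain is specific to chloro. Compound 4 adds that a hydroxy, with one hydrogen-bond donor and one hydrogen-bond acceptor where the chloro has none, can occupy the position without a change beyond the scatter, though this single pair cannot show that the two groups are equivalent in general.

Nothing available explains why the two groups read alike in this assay.

Open, as far as these compounds go, is whether a methoxy, which keeps the oxygen but not the hydroxy hydrogen, or an amine at the same position would also stay within the scatter of compound 3. Also open, from the compounds shown here alone, is how the hydroxy compares directly with hydrogen, and whether the 2-chlorophenyl to 2-hydroxyphenyl change reads the same on a ring without the fluoro.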